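The source may report more compounds than this note shows. Statements on the series, on what has been measured and on what is new or still open speak of the compounds shown alone.

The measured compounds:

Compound 1, `COc1ccc(C(=O)Nc2ccc3ncc(-c4cnn(C)c4)cc3n2)cc1`, which in a functional assay on HeLa cells (Homo sapiens) for antiproliferative activity, read by MTT assay, with a stated time of 48 h (a higher number here means a weaker inhibitor, a lower number a stronger inhibitor), gives 4900 nM.
Compound 2, `Cn1cc(-c2cnc3ccc(NC(=O)c4cccnc4)nc3c2)cn1`, for which this assay reports only the limit > 50000 nM.
Compound 3, `COc1ccc(C(=O)Nc2nccc3ncc(-c4cnn(C)c4)cc23)cc1`, for which this assay likewise reports only the limit > 50000 nM.

Compound 1 and compound 2 share one core and differ in a single place: pyridin-3-yl in place of 4-methoxyphenyl on a carbonyl carbon. That change produces an at least 10-fold higher number from compound 1 to compound 2 (1.00 log units; beyond the scatter). The step ends at the limit of > 50000 nM in this assay, at which 2 of the 3 values shown sit, so it shows only how far the loss reached before the assay stopped counting.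

Compound 3 is built from the same atoms as compound 1, joined differently; the difference between the two cores is not broken down here. Compound 4, `Cn1cc(-c2cnc3ccnc(NC(=O)c4cccnc4)c3c2)cn1`, stands to compound 3 as compound 2 stands to compound 1: pyridin-3-yl in place of 4-methoxyphenyl on a carbonyl carbon. The place is described in the same words for both pairs, so this is the same change on a second core.

The expectation for compound 4 rests on two things. Compound 3 already sits at the limit > 50000 nM. The same change weakened the first pair, as the step of an at least 10-fold higher number from compound 1 to compound 2 (1.00 log units; beyond the scatter) shows. In this assay compound 4 is therefore expected to give about 100000 nM, most likely reported as a limit, between 50000 nM and 400000 nM. The expected step is a step that the limit leaves unreadable from compound 3 to compound 4, because the same change gave an at least 10-fold higher number from compound 1 to compound 2 (1.00 log units; beyond the scatter) and compound 3 offers no measured room to lose.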

Compound 4, half-maximal inhibitory concentration: > 50000 nM
Compound 4: only a limit was reported (the forecaster's own chance of this, stated with the estimate: 90%); the middle value does not contradict the limit.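

Compound 3 and compound 4 both stop at a limit of this assay rather than at a number, so no new step can be read between them: the limit of > 50000 nM in this assay, at which 3 of the 4 values shown sit.

The compounds shown leave open what pyridin-3-yl in place of 4-methoxyphenyl does on the core of compound 3, and where compound 2, compound 3 and compound 4 would lie beyond that limit.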